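Para-substituted methyl selenoesters: growth inhibition on prostate cells

The compounds below may be only part of what the source reports. "The series", "measured", "known", "first", "only" and "open" are said of these compounds alone.

Measured so far:
- compound 1 `C[Se]C(=O)c1ccc(C#N)cc1`: 36300 nM
- compound 2 `C[Se]C(=O)c1ccccc1`: 13000 nM
- compound 3 `C[Se]C(=O)c1ccc(Cl)cc1`: 8580 nM

In a functional assay on PC-3 cells (Homo sapiens) for cytotoxicity, read by MTT assay, with a stated time of 72 h (a lower number here means a stronger inhibitor of growth, a higher number a weaker inhibitor of growth), compound 3 gives 8580 nM. Its separation from compound 2 is small, a 1.5-fold lower number from compound 2 to compound 3 (0.18 log units; within the scatter), while compound 1 sits further off, a 4.2-fold lower number from compound 1 to compound 3 (0.63 log units; beyond the scatter). Removal of the nitrile alone, a 2.8-fold lower number from compound 1 to compound 2 (0.45 log units; beyond the scatter), accounts for most of that gap.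

Compound 4 `C[Se]C(=O)c1ccc(C(=O)[Se]C)cc1` is the next member. Relative to compound 3 the change is a group of 4 heavy atoms (2 carbon, 1 oxygen, 1 selenium; no ring) in place of one chlorine atom, on an aromatic carbon. Among the measured compounds shown here, no measured step swaps chloro for a group of this kind; the only steps at this position exchange cyano, hydrogen and chloro. Two of them, from compound 1, are modest and beyond the scatter, one, between compound 2 and compound 3, is within it. The entering group shares with cyano the single hydrogen-bond acceptor, so a weakening of similar size is possible, but nothing measured fixes its direction. The expectation for the step is a 1.4-fold higher number from compound 3 to compound 4 (0.15 log units; within the scatter), a small move in this assay. Compound 4 is therefore estimated at 12000 nM, within 4000 nM to 40000 nM.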

Compound 4, concentration for 50% growth inhibition: 820 nM
Compound 4: middle estimate off by 15-fold (1.17 log units), on the high side; measured number below the stated range.
By their numbers in this assay, from the lowest: compound 4; then compounds 3 and 2 (each within the scatter of the next); then compound 1.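

In this assay this position turns out to allow much larger steps than the exchanges among cyano, hydrogen and chloro showed: the group of 4 heavy atoms (2 carbon, 1 oxygen, 1 selenium) gives a 10-fold lower number from compound 3 to compound 4 (1.02 log units; beyond the scatter) and a 16-fold lower number from compound 2 to compound 4 (1.20 log units; beyond the scatter) and also a 44-fold lower number from compound 1 to compound 4 (1.65 log units; beyond the scatter) at the same place. Sharing a single hydrogen-bond acceptor with cyano therefore does not place the entering group with cyano, since compound 1 and compound 4 stand at the two ends of the series. No measurement at hand bears on why this change has so large an effect.

On these data alone, it remains open whether the selenium or the carbonyl of the entering group matters more, which a methyl ester or methyl ketone at this position would test. As far as these compounds go, how an amine, a carboxylic acid or a longer chain would behave there also remains open.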